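This account rests on a few compounds, and the source may have more. Where it says the series, first, only, none or still open, it means among the compounds named here.

Measured in a functional assay on NCI-H460 cells (Homo sapiens) for inhibition, read by MTT assay, with a stated time of 24 h, tested at 100 ug/mL; on this read-out lower numbers stand for less inhibition of growth and higher numbers for more inhibition of growth at the one concentration tested:
- Compound 1 `CC(=O)SCCC(CCCCC(=O)O)SC(C)=O`: 11%
- Compound 2 `O=C(CCCCC1CCSS1)NO`: "not active" (no number reported)
- Compound 3 `O=C(CCCCC1CCSS1)Nc1cccc(C(F)(F)F)c1`: 68.8%

Compound 2 has no figure of its own. Its result reads "not active" (no number reported), so it cannot be placed exactly on the scale set by the other two compounds. Compound 1 gives 11% and compound 3 gives 68.8%, a wide gap between those two values.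

The next compound to be tested is compound 4 `O=C(CCCCC1CCSS1)Nc1ccccn1`. The change is pyridin-2-yl in place of hydroxy on an amide-type nitrogen, which puts pyridin-2-yl in place of hydroxy on an amide-type nitrogen. Among the measured compounds shown here, no measured pair in this small set isolates that change, so any forecast rests on thin evidence.

In this assay an upward step beyond the usual scatter is expected, from a compound reported as not active to a moderate level of growth inhibition. For the measured compounds named here, the main support is compound 3 at 68.8%, the only measured compound with an aromatic group on that nitrogen. Going by the values given here, its group differs from the one in compound 4, so a result short of that value is expected, and a wide range is warranted.

The estimated value for compound 4 is 40%, with an expected range from 15% to 70%.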

Compound 4, percent growth inhibition at one concentration: 39.3%
Beside the measured number, compound 4's estimate is 0.7 percentage points above it; the range from low to high includes it.
By their numbers in this assay, from the lowest: compound 1; then compound 4; then compound 3.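

In this assay, among the compounds shown here, compound 2 is reported only as not active, without a number, so its comparison with compound 4 at 39.3% gives no step that can be read. The compounds shown leave open how other groups on the amide-type nitrogen would compare with pyridin-2-yl. No measurement shown offers an explanation for this result.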